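The compounds below may be only part of what the source reports. "The series", "measured", "known", "first", "only" and "open" are said of these compounds alone.

Three compounds have been measured in a functional assay on SW 1116 cells (Homo sapiens) for antiproliferative activity, read by MTT assay, with a stated time of 24 h; on this read-out higher numbers stand for weaker inhibition and lower numbers for stronger inhibition:
compound 1, `Clc1ccccc1CSc1nnc(-c2ccc3c(c2)OCCO3)n1-c1ccccc1`, 9670 nM
compound 2, `Fc1ccccc1CSc1nnc(-c2ccc3c(c2)OCCO3)n1-c1ccccc1`, 13600 nM
compound 3, `Fc1ccc(CSc2nnc(-c3ccc4c(c3)OCCO4)n2-c2ccccc2)c(F)c1`, 7830 nM

On these numbers compound 1 stands second highest of three, with compound 3 nearest at a 1.2-fold lower number from compound 1 to compound 3 (0.09 log units; within the scatter) and compound 2 furthest at a 1.4-fold higher number from compound 1 to compound 2 (0.15 log units; within the scatter); every gap lies within the scatter, so none of the three can be set apart. Compound 4, `Brc1ccc(CSc2nnc(-c3ccc4c(c3)OCCO4)n2-c2ccccc2)cc1`, is not yet measured. It differs from compound 1 in one place: 4-bromophenyl in place of 2-chlorophenyl on a saturated chain carbon bound to a sulfur. Going by the values given here, the steps that bear on this change all exchange the group on the saturated chain carbon bound to a sulfur: a 1.4-fold higher number from compound 1 to compound 2 (0.15 log units; within the scatter), a 1.2-fold lower number from compound 1 to compound 3 (0.09 log units; within the scatter) and a 1.7-fold lower number from compound 2 to compound 3 (0.24 log units; within the scatter), none beyond the scatter. Compound 4 is therefore expected to show a 1.0-fold lower number from compound 1 to compound 4 (0.01 log units; within the scatter). The estimate for compound 4 in this assay is 9500 nM, ranging from 4000 nM to 22000 nM.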

Compound 4, half-maximal inhibitory concentration: 5810 nM
Compound 4: the middle estimate sits 1.6-fold (0.21 log units) above what was measured; the range from low to high includes it.
By their numbers in this assay, from the lowest: compounds 4, 3, 1 and 2 (each within the scatter of the next, the first and the last beyond it).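

In this assay, going by these compounds alone, the change to 4-bromophenyl on the saturated chain carbon bound to a sulfur gives the first step at this position to lie beyond the scatter, though a modest one (a 2.3-fold lower number from compound 2 to compound 4 (0.37 log units; beyond the scatter)). The two other new steps stay within the scatter (a 1.7-fold lower number from compound 1 to compound 4 (0.22 log units; within the scatter); a 1.3-fold lower number from compound 3 to compound 4 (0.13 log units; within the scatter)), so compound 4 is set apart from compound 2 alone. Nothing measured on hand accounts for that step. As far as these compounds go, whether the halogen or its place on the ring matters remains open, and 4-chlorophenyl or 2-bromophenyl would separate the two. From the compounds shown here alone, how a carboxylic acid or an amine on this ring would read is also open.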